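The source may hold more compounds than are shown below. What is called first, only, known or untested is meant among the compounds shown, and "the series" means these compounds.

Measured so far in a functional assay on MCF7 cells (Homo sapiens) for antiproliferative activity, read by CellTiter-Glo, with a stated time of 5 days; on this read-out higher numbers stand for weaker inhibition and lower numbers for stronger inhibition:

- Compound 1 (`CC/C(=C(/c1ccc(/C=C/C(=O)O)cc1)c1ccc2cncn2c1)c1ccccc1`) gives > 500 nM as a limit, not a number
- Compound 2 (`CC/C(=C(/c1ccc(/C=C/C(=O)O)cc1)c1ccc2nnnn2c1)c1ccccc1`) gives > 500 nM as a limit, not a number
- Compound 3 (`O=C(O)/C=C/c1ccc(/C(=C(\c2ccc(F)cc2Cl)C2CCC2)c2ccc3scnc3c2)cc1`) gives 3 nM as a true number

Within the data shown here, compound 3 holds the only true number in this small set. Compounds 1 and 2 report only a limit (the limit of > 500 nM in this assay, at which 2 of the 3 values shown sit).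

The next molecule, compound 4 (`O=C(O)/C=C/c1ccc(/C(=C(\c2ccc(C(F)(F)F)cc2Cl)C2CCC2)c2ccc3scnc3c2)cc1`), changes one group of compound 3. The difference is trifluoromethyl in place of fluoro on an aromatic carbon, which turns a 2-chloro-4-fluorophenyl into a 2-chloro-4-(trifluoromethyl)phenyl. The group sits para to a large group and meta to a chloro group.

Among the measured compounds shown here, the one measured step, a step that the two limits leave unreadable from compound 1 to compound 2, concerns a different group, and its size cannot be read. For the measured compounds named here, no measured step therefore bears on this change, and the forecast rests on compound 3 alone. With compound 3 at 3 nM in this assay, a low number, any drift seems more likely to go towards weaker inhibition than towards stronger. The expected 1.7-fold higher number from compound 3 to compound 4 (0.22 log units; within the scatter) is small and may not exceed the usual scatter. For compound 4 the estimate is 5 nM (expected range 1.5 nM to 20 nM).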

Compound 4, half-maximal inhibitory concentration: 2.6 nM
Beside the measured number, compound 4's estimate is 1.9-fold (0.28 log units) above it, and the stated range covers the measured number.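

In this assay, putting trifluoromethyl in place of fluoro gives a 1.2-fold lower number from compound 3 to compound 4 (0.06 log units; within the scatter), so the two compounds cannot be told apart. Among these compounds, this is the first step with a readable size in the set, and it concerns a position on an aromatic carbon, para to a large group and meta to a chloro group. Here, the group that enters holds more heavy atoms than the group that leaves, and compound 4 still gives 2.6 nM, so in this one pair the larger group costs nothing that can be measured. Nothing among the measurements at hand accounts for how closely the two values agree.

The compounds shown leave open how a nitrile, a methoxy group or an amine would read at this same position, and so how far the tolerance seen with these two groups extends. They also leave open whether trifluoromethyl would read the same on a ring that lacks the chloro group, or with something other than the cyclobutyl ring on the shared core.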